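A few compounds are considered here, and "the series" means these few. Any claim that something is new, unique, unknown or untested is made for them only; others in the source may bear on it.

Measured compounds in an assay on isolated protein for inhibition of histone deacetylase 4 (Homo sapiens), with a stated time of 1 h; on this read-out higher numbers stand for weaker inhibition and lower numbers for stronger inhibition:
compound 1 `Cc1ccc(NC(=O)COc2ccc3cc(/C=C4/SC(=O)NC4=O)ccc3c2)cc1` gives 1700 nM
compound 2 `CCOc1ccc2nc(NC(=O)COc3ccc4cc(/C=C5/SC(=O)NC5=O)ccc4c3)sc2c1` gives 3600 nM
compound 3 `Cc1cc(Br)ccc1NC(=O)COc1ccc2cc(/C=C3/SC(=O)NC3=O)ccc2c1` gives 550 nM

Compound 3 carries the lowest number of the three in this assay. Its nearest neighbour is compound 1, at 1700 nM, a difference beyond the scatter; compound 2, at 3600 nM, lies furthest away, also beyond the scatter.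

Compound 4 `O=C(COc1ccc2cc(/C=C3/SC(=O)NC3=O)ccc2c1)Nc1c(F)cc(F)cc1Br` is not yet measured. It differs from compound 3 in one place: 2-bromo-4,6-difluorophenyl in place of 4-bromo-2-methylphenyl on an amide-type nitrogen. Among the measured compounds shown here, the only step that touches the same position is a 3.1-fold lower number from compound 1 to compound 3 (0.49 log units; beyond the scatter), a modest gain on moving from 4-methylphenyl to 4-bromo-2-methylphenyl. For the measured compounds named here, no measured pair tests fluorine at this position, nor a move of the bromine from the 4- to the 2-position, so the direction of the new step is not fixed by the data. Retaining a bromine while exchanging methyl for two fluorines is taken as roughly neutral to slightly unfavourable; the expected step is a 1.6-fold higher number from compound 3 to compound 4 (0.21 log units; within the scatter). Compound 4 is therefore estimated at 900 nM in this assay, with a range of 300 nM to 2700 nM.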

Compound 4, half-maximal inhibitory concentration: 1100 nM
Estimate against measurement, compound 4: 1.2-fold (0.09 log units) below; low and high end bracket the measured number.
By their numbers in this assay, from the lowest: compounds 3, 4 and 1 (each within the scatter of the next, the first and the last beyond it); then compound 2.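

In this assay the amide-type nitrogen accepts 2-bromo-4,6-difluorophenyl in place of 4-bromo-2-methylphenyl with the step being a 2.0-fold higher number from compound 3 to compound 4 (0.30 log units; within the scatter), so this exchange cannot be told apart from no effect. The same group in place of 4-methylphenyl gives a 1.5-fold lower number from compound 1 to compound 4 (0.19 log units; within the scatter), so compound 4 cannot be separated from either compound 1 or compound 3, although those two lie beyond the scatter of each other, and it does not settle whether the gain seen with compound 3 is kept. No supporting evidence bears on either step.

The compounds shown leave open what the methyl, each fluorine and the placing of the bromine contribute singly, since compound 4 alters all of them in one step. Going by these compounds, how an amine or a carboxylic acid on this phenyl group would read also remains open.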